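Replacing trifluoromethyl with 1-hydroxyethyl in compound 1

A few compounds are considered here, and "the series" means these few. Any claim that something is new, unique, unknown or untested is made for them only; others in the source may bear on it.

In an ADME assay on microsomes from liver (Rattus norvegicus) for metabolic stability, read by LC-MS, using NADPH, with stated times of 6 min and 10 min, tested at 0.5 uM (on this read-out higher numbers stand for a more stable compound and lower numbers for a less stable compound), compound 1 `CC(=O)N1CCN(c2cc(-c3cc(Cl)c4c(N)ncnn34)ccc2C(F)(F)F)C(=O)C1(C)C` gives 87%. Compound 2 `COc1ccc(-c2cc(Cl)c3c(N)ncnn23)cc1N1CCN(C(C)=O)C(C)(C)C1=O` gives 91%, which is within the scatter of compound 1, while compound 3 `CC(=O)N1CCN(c2cc(-c3cc(Cl)c4c(N)ncnn34)ccc2S(C)(=O)=O)C(=O)C1(C)C` gives 100%, clearly above it. Compound 4 `CC(=O)N1CCN(c2cc(-c3cc(Cl)c4c(N)ncnn34)ccc2C(C)O)C(=O)C1(C)C` has 1-hydroxyethyl in place of trifluoromethyl on an aromatic carbon. Two measured changes also replace that trifluoromethyl: methoxy gives a number 4 percentage points higher from compound 1 to compound 2 (within the scatter), and methylsulfonyl gives a number 13 percentage points higher from compound 1 to compound 3 (beyond the scatter). Only the second lies beyond the scatter, and it is modest. Neither brings in 1-hydroxyethyl, so no clear change is expected. The expected step is a number 2 percentage points lower from compound 1 to compound 4 (within the scatter). For compound 4 the estimate is 85%, with an expected range from 70% to 97%.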

Compound 4, percent of the compound remaining: 100%
Beside the measured number, compound 4's estimate is 15 percentage points below it; the whole stated range lies below it.
By their numbers in this assay, from the lowest: compounds 1, 2, 3 and 4 (each within the scatter of the next, the first and the last beyond it).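

In this assay, putting 1-hydroxyethyl at this position in place of trifluoromethyl gives a number 13 percentage points higher from compound 1 to compound 4 (beyond the scatter), so a group carrying a hydrogen-bond donor and a hydrogen-bond acceptor is accepted here. Against methylsulfonyl the result is no change at the digits printed from compound 3 to compound 4 (within the scatter), and against methoxy it is a number 9 percentage points higher from compound 2 to compound 4 (within the scatter). These three replacements therefore cannot be ranked, although methylsulfonyl and 1-hydroxyethyl both stand clear of trifluoromethyl. On these data alone, whether an amine or a carboxylic acid at this position would behave the same way stays open. What lies behind the rise from trifluoromethyl also stays open, as nothing measured here speaks to it.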